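Aryl substituent series on a shared tricyclic core

A few compounds are considered here, and "the series" means these few. Any claim that something is new, unique, unknown or untested is made for them only; others in the source may bear on it.

Three members of the series share one core and differ only in the group carried on the pendant aromatic ring. Compound 1 `CCCc1ccc(N2C(=O)NC3(CSC4=C3C(=O)c3ncccc3C4=O)C2=O)cc1` gives 300 nM in a functional assay on SF-268 cells (Homo sapiens) for antiproliferative activity, read by MTT assay, with a stated time of 96 h; a lower number here means a stronger inhibitor, a higher number a weaker inhibitor. Compound 2 `O=C1C2=C(C(=O)c3ncccc31)C1(CS2)NC(=O)N(c2ccc(Cl)cc2)C1=O` gives 580 nM in this assay, and compound 3 `O=C1C2=C(C(=O)c3ncccc31)C1(CS2)NC(=O)N(c2ccc([N+](=O)[O-])cc2)C1=O` gives 1520 nM. Within this set compound 3 carries the highest number: the step of a 1.9-fold higher number from compound 1 to compound 2 (0.29 log units; within the scatter) stays within the scatter, whereas a 5.1-fold higher number from compound 1 to compound 3 (0.70 log units; beyond the scatter) and a 2.6-fold higher number from compound 2 to compound 3 (0.42 log units; beyond the scatter) both lie beyond it.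

Compound 4 `CCCCCc1ccc(N2C(=O)NC3(CSC4=C3C(=O)c3ncccc3C4=O)C2=O)cc1` is the next member awaiting measurement in this assay. The change from compound 3 is pentyl in place of nitro on an aromatic carbon. The step that bears most directly on it is the one in the opposite sense, a 5.1-fold higher number from compound 1 to compound 3 (0.70 log units; beyond the scatter), where propyl gave way to nitro; the present change reverses that swap while lengthening the chain from propyl to pentyl, a lengthening for which no comparison exists within the measured compounds. On the strength of the propyl-to-nitro step alone, compound 4 is expected to sit near compound 1, with a step of a 4.6-fold lower number from compound 3 to compound 4 (0.66 log units; beyond the scatter) expected, a lowering of the number beyond the scatter. The estimate for compound 4 is therefore 330 nM, with a range of 120 nM to 900 nM.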

Compound 4, half-maximal inhibitory concentration: 520 nM
Compound 4: the middle estimate sits 1.6-fold (0.20 log units) below what was measured, and the stated range covers the measured number.
By their numbers in this assay, from the lowest: compounds 1, 4 and 2 (each within the scatter of the next); then compound 3.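

In this assay, the aromatic carbon para to a large group tolerates lengthening of the chain from propyl to pentyl with no separable change: a 1.7-fold higher number from compound 1 to compound 4 (0.24 log units; within the scatter) gives the series its first comparison of chain length, and that comparison stays within the scatter. Pentyl and chloro cannot be told apart at this position either, with a 1.1-fold lower number from compound 2 to compound 4 (0.05 log units; within the scatter), so three quite different groups now give values within the scatter of one another, while a 2.9-fold lower number from compound 3 to compound 4 (0.47 log units; beyond the scatter) shows that nitro stands apart from pentyl as it does from propyl and chloro, leaving compound 3 the weakest of the four. Nothing measured here speaks to what lies behind these differences.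

On these data alone, it remains open whether a chain longer than pentyl, or a shorter one such as methyl, stays at this level or whether a limit to chain length appears. An amine or a carboxylic acid at the same carbon would show whether nitro is a lone exception or one of a wider set of groups that raise the number.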